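The source may report more compounds than this note shows. Statements on the series, on what has been measured and on what is new or still open speak of the compounds shown alone.

Measured so far:
compound 1 `CC(C#Cc1cccc(C(=O)NCCC(c2ccccc2)c2ccccc2)c1)N(O)C(N)=O`: 300 nM
compound 2 `CCC(C#Cc1cccc(C(=O)NCc2ccccc2C(F)(F)F)c1)N(O)C(N)=O`: 500 nM

In an assay for inhibition of Polyunsaturated fatty acid 5-lipoxygenase (Homo sapiens), read by HPLC, with stated times of 15 min and 10 min (on this read-out lower numbers stand for stronger inhibition and higher numbers for weaker inhibition), compound 1 gives 300 nM and compound 2 gives 500 nM; the two numbers lie within the scatter of each other, so neither compound is set apart by this read-out. Compound 3 `CC(C)CC(C#Cc1cccc(C(=O)NCc2ccccc2C(F)(F)F)c1)N(O)C(N)=O` is not yet measured. It differs from compound 2 by isopropyl in place of methyl on a saturated chain carbon, two bonds along the chain from an amide-type nitrogen and a triple-bonded carbon. For the measured compounds named here, no measured pair shows what this change does, so the step is expected to be small and not beyond the scatter, in either direction. The step expected here is a 1.1-fold lower number from compound 2 to compound 3 (0.05 log units; within the scatter). Compound 3 is estimated at 450 nM, with a range from 150 nM to 1300 nM.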

Compound 3, half-maximal inhibitory concentration: 600 nM
The estimate for compound 3 lay 1.3-fold (0.12 log units) below the measured number; low and high end bracket the measured number.
By their numbers in this assay, from the lowest: compounds 1, 2 and 3 (each within the scatter of the next).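

Isopropyl in place of methyl on a saturated chain carbon, two bonds along the chain from an amide-type nitrogen and a triple-bonded carbon, gives a 1.2-fold higher number from compound 2 to compound 3 (0.08 log units; within the scatter) in this assay and is the first reading of any change at this position. This carbon thus carries the branched group with no step beyond the scatter. No supporting evidence bears on this result. 

Still open, from the compounds shown here alone, is whether an amine, a carboxylic acid or a longer chain on this carbon moves the number beyond the scatter. Also open, going by these compounds, is whether the same change reads alike on the amide side of compound 1.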